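Compound 4 Against a Cytotoxicity Limit

The source may report more compounds than this note shows. Statements on the series, on what has been measured and on what is new or still open speak of the compounds shown alone.

Compound 1 `C=C[C@@](C)(/C=C/c1ccc(OC)cc1)CCC=C(C)C`: > 36600 nM (a limit)
Compound 2 `C=C[C@@](C)(/C=C/c1ccc(O)cc1)CCC1OC1(C)C`: > 36600 nM (a limit)
Compound 3 `C=C[C@@](C)(/C=C/c1ccc(O)cc1)CC/C=C/C(=O)OCc1ccccc1`: > 36600 nM (a limit)

These readings come from an ADME assay on BJ cells (Homo sapiens) for cytotoxicity, with a stated time of 72 h (on this read-out higher numbers stand for an effect only at larger amounts of compound and lower numbers for an effect already at smaller amounts), and none of them is an exact number. Compound 2 stands at > 36600 nM as a limit, not a number. Its two companions share that position, and the whole record is the limit of > 36600 nM in this assay, at which 3 of the 3 values shown sit, here. Compound 4 `C=C[C@@](C)(/C=C/c1ccc(O)cc1)CC/C=C(\C)C=O` differs from compound 2 in one place: 2-formylprop-1-en-1-yl in place of 3,3-dimethyloxiran-2-yl on a saturated chain carbon, three bonds along the chain from two double-bonded chain carbons. Going by the values given here, no step between measured compounds is available as a guide. In this assay the expected step of an at least 1.2-fold lower number from compound 2 to compound 4 (0.08 log units; that floor lies within the scatter) is none beyond the scatter, and any shift would be expected toward lower numbers. Compound 4 is estimated at 30000 nM, with 12000 nM to 60000 nM as the expected range.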

Compound 4, half-maximal effective concentration: > 36600 nM
Compound 4: a limit, no number (the forecaster's own chance of this, stated with the estimate: 65%); middle value at least 1.2-fold (0.08 log units) away from the limit.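

Compound 4 gives > 36600 nM in this assay as a limit, not a number. Going by these compounds alone, compound 2 also sits at a limit, so no step from compound 2 to compound 4 can be read. In this assay the compounds shown leave open at what concentration any of them would take effect.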